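Ester to Carboxymethyl: Expectation for Compound 4 at Orexin-1

The source may report more compounds than this note shows. Statements on the series, on what has been measured and on what is new or still open speak of the compounds shown alone.

Measured so far:
compound 1 `COC(=O)c1ccc2ccc(C(=O)c3ccccc3)c-2cc1`, 7.2%
compound 2 `COC(=O)c1ccc2ccc(C(=O)c3ccc(C(F)(F)F)cc3)c-2cc1`, -60.5%
compound 3 `NC(=O)c1ccc2c(C=O)cc(-c3ccccc3)c-2cc1`, 6.1%

In an assay on cells for displacement of a labelled ligand from Orexin/Hypocretin receptor type 1 (Homo sapiens), read by scintillation counting, with stated times of 10 min and 90 min, tested at 10 uM (on this read-out lower numbers stand for less inhibition and higher numbers for more inhibition at the one concentration tested (going by the name of the read-out)), compound 1 gives 7.2%. Compound 2 gives -60.5%, the lowest of the three numbers, and both others lie beyond the scatter from it: compound 3 gives 6.1%. Among the measured compounds shown here, the single step measured between compounds that differ in one place is a number 67.7 percentage points lower from compound 1 to compound 2 (beyond the scatter), which came with trifluoromethyl in place of hydrogen on an aromatic carbon.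

Compound 4 `O=C(O)Cc1ccc2ccc(C(=O)c3ccc(C(F)(F)F)cc3)c-2cc1` differs from compound 2 by carboxymethyl in place of methoxycarbonyl on an aromatic carbon. For the measured compounds named here, no measured step involves this exchange; compound 3 carries an amide in place of an ester but also differs from compound 2 elsewhere, so only its value and that of compound 2 can be set side by side. Going by the values given here, with no step to lean on, the expectation rests on compound 2 alone, whose -60.5% is the starting point, and on wide uncertainty. Compound 4 is therefore estimated at -15%, with a range from -55% to 25%. The step of a number 45.5 percentage points higher from compound 2 to compound 4 (beyond the scatter) is expected as a move upward, but the range admits no change beyond the scatter.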

Compound 4, a percentage reported as inhibition, at one concentration (the size of the read-out at that concentration, not a potency): 8.6%
For compound 4 the middle estimate is 23.6 percentage points below the measured one, and the stated range covers the measured number.
By their numbers in this assay, from the lowest: compound 2; then compounds 3, 1 and 4 (each within the scatter of the next).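

Among the compounds shown here, this is the first measured change at this place, an aromatic carbon of the seven-membered ring, and in this assay it matters: the step is a number 69.1 percentage points higher from compound 2 to compound 4 (beyond the scatter). The exchange keeps the same atoms and the same heavy-atom count, joined differently, so rearranging methoxycarbonyl into carboxymethyl is enough to shift the read-out, and carboxymethyl brings a hydrogen-bond donor that methoxycarbonyl lacks. No supporting measurement is available to explain why the number moves.

As far as these compounds go, it remains open whether the same exchange would give a similar step on the core of compound 1, which has no trifluoromethyl group. From the compounds shown here alone, it is also open how an amine or a longer chain such as carboxyethyl would read at this place, and each number here, taken at one concentration, is not a potency.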